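The compounds below may be only part of what the source reports. "The series", "measured", "known", "first", "only" and "open" are said of these compounds alone.

Compound 1 `O=C(Nc1ccc(Cl)cc1)N1CCC[C@H]1c1nc(-c2ccccc2)no1`, compound 2 `O=C(Nc1ccc(I)cc1)N1CCC[C@H]1c1nc(-c2ccccc2)no1` and compound 3 `O=C(Nc1ccc(OC(F)(F)F)cc1)N1CCC[C@H]1c1nc(-c2ccccc2)no1` share one core and differ only in a single group on an aromatic ring, which is chloro, iodo or trifluoromethoxy. In an ADME assay on MCF-10A cells (Homo sapiens) for inhibition, with a stated time of 48 h (on this read-out lower numbers stand for stronger inhibition and higher numbers for weaker inhibition), compound 1 gives > 50000 nM, which is a limit and not a number. Compound 2 gives > 50000 nM, again a limit. Compound 3 gives > 50000 nM, also a limit. Compound 1 therefore has no exact position, and the only mark for the whole set is the limit of > 50000 nM in this assay, at which 3 of the 3 values shown sit. The three exchanges yield a step that the two limits leave unreadable from compound 1 to compound 2, then a step that the two limits leave unreadable from compound 1 to compound 3, and finally a step that the two limits leave unreadable from compound 2 to compound 3. None of them gives a size to carry forward, and none touches the phenyl group that changes next.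

Compound 4 `O=C(Nc1ccc(Cl)cc1)N1CCC[C@H]1c1nc(-c2ccccc2Br)no1` turns that phenyl into 2-bromophenyl, with bromo in place of hydrogen on an aromatic carbon. Since compound 1 sits at > 50000 nM, which is only a limit, no step beyond the scatter and no clear direction can be expected in this assay. The expected change is a step that the limit leaves unreadable from compound 1 to compound 4. For compound 4 the estimated value is 60000 nM, with an expected range from 25000 nM to 120000 nM, and another limit is the likeliest report.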

Compound 4, half-maximal inhibitory concentration: > 50000 nM
Compound 4: only a limit was reported (the forecaster's own chance of this, stated with the estimate: 85%); the middle value lies beyond the limit too.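

In this assay compound 4 gives > 50000 nM, which is a limit and not a number. Compound 1 also stands only at a limit, so no size or direction can be read for the change from compound 1 to compound 4, and the set shares one mark: the limit of > 50000 nM in this assay, at which 4 of the 4 values shown sit.

The compounds shown leave open what exact value any of them has in this assay, and whether the added bromo changes it at all.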